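Ether side chain variation in a receptor antagonist series

The source may hold more compounds than are shown below. What is called first, only, known or untested is meant among the compounds shown, and "the series" means these compounds.

compound 1 `Cn1nc(-c2ccc(OCC34CCC(O)(CC3)CC4)c(F)c2)c2cnc(N)nc21` — 5300 nM
compound 2 `Cc1cc(-c2ccc(OCC34CCC(N)(CC3)CC4)c(F)c2)c2cnc(N)nn12` — 3400 nM

In an assay on tissue (PBMC cells) for antagonist activity at Toll-like receptor 9 (Homo sapiens) (a lower number here means a stronger inhibitor, a higher number a weaker inhibitor), compound 1 gives 5300 nM, the higher of the two numbers recorded so far. Compound 2 gives 3400 nM in this assay, and the gap between the two lies within the scatter, so no order between them is claimed.

Compound 3 `Cn1nc(-c2ccc(OCCCC3CCNCC3)c(F)c2)c2cnc(N)nc21` has not yet been measured in this assay. It differs from compound 1 as follows: a group of 8 heavy atoms (7 carbon, 1 nitrogen; one six-membered non-aromatic ring with 1 hetero atom) in place of a group of 9 heavy atoms (8 carbon, 1 oxygen; 2 six-membered non-aromatic rings of carbon only), on a saturated chain carbon bound to an oxygen on an aromatic ring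

For the measured compounds named here, no measured pair covers a change of this kind, so the size of the step rests on the two numbers alone. The expected step is a 1.8-fold lower number from compound 1 to compound 3 (0.25 log units; within the scatter), toward a lower number but close to the scatter. Compound 3 is estimated at 3000 nM, with a range from 1000 nM to 10000 nM.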

Compound 3, half-maximal inhibitory concentration: 2300 nM
Compound 3: the middle estimate sits 1.3-fold (0.12 log units) above what was measured; measured number inside the range.
By their numbers in this assay, from the lowest: compounds 3, 2 and 1 (each within the scatter of the next, the first and the last beyond it).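

In this assay, 2-(piperidin-4-yl)ethyl in place of the group with 2 six-membered non-aromatic rings of carbon only gives a 2.3-fold lower number from compound 1 to compound 3 (0.36 log units; beyond the scatter) on a saturated chain carbon bound to an oxygen on an aromatic ring. For the compounds shown here, this is the first single-place change, and it shows that this position accepts a ring with a nitrogen without a rise in the number. No measured property bears on the step.

The ring nitrogen and the change in ring count arrive together, so neither can be credited alone. Going by these compounds, how a longer chain to the piperidine or a carboxylic acid at this position would read remains open.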